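Isopropoxy for Methylsulfanyl on the Shared Core

This account rests on a few compounds, and the source may have more. Where it says the series, first, only, none or still open, it means among the compounds named here.

Compound 1: `Cc1[nH]c2ccc(OS(=O)(=O)C(F)(F)F)cc2c1C1=CCNCC1`, 50 nM
Compound 2: `CSc1ccc2[nH]c(C)c(C3=CCNCC3)c2c1`, 20 nM

In an assay on HEK293 cells for displacement of a labelled ligand from 5-hydroxytryptamine receptor 6 (Homo sapiens), read by scintillation counting, with a stated time of 1 h (a higher number here means a weaker inhibitor, a lower number a stronger inhibitor), compound 2 gives 20 nM, the lowest of the two numbers; its nearest neighbour is compound 1 at 50 nM. Compound 3 `Cc1[nH]c2ccc(OC(C)C)cc2c1C1=CCNCC1` differs from compound 2 by isopropoxy in place of methylsulfanyl on an aromatic carbon. Within the data shown here, the only step at this position, a 2.5-fold lower number from compound 1 to compound 2 (0.40 log units; beyond the scatter), was modest. Among the measured compounds shown here, no measured pair tests isopropoxy against methylsulfanyl, so for compound 3 a step of at most modest size in either direction is expected, a 1.5-fold higher number from compound 2 to compound 3 (0.18 log units; within the scatter). Compound 3 is therefore estimated at 30 nM, between 8 nM and 110 nM.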

Compound 3, half-maximal inhibitory concentration: 100 nM
For compound 3 the middle estimate is 3.3-fold (0.52 log units) below the measured one, and the stated range covers the measured number.
By their numbers in this assay, from the lowest: compound 2; then compounds 1 and 3 (each within the scatter of the next).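

In this assay, the change from methylsulfanyl to isopropoxy on this aromatic carbon gives a step beyond the scatter (a 5.0-fold higher number from compound 2 to compound 3 (0.70 log units; beyond the scatter)), so compound 2 alone stands apart from both other compounds. Compound 3 and compound 1 do not separate (a 2.0-fold higher number from compound 1 to compound 3 (0.30 log units; within the scatter)), which leaves the two oxygen-linked groups indistinguishable here. No evidence is available to explain this result.

The change swaps sulfur for oxygen and also goes from 2 to 4 heavy atoms, so the two are not separated. Methoxy and ethylsulfanyl at this position would be the groups to tell them apart.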